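This account rests on a few compounds, and the source may have more. Where it says the series, first, only, none or still open, it means among the compounds named here.

In a functional assay on MGC-803 cells (Homo sapiens) for inhibition (on this read-out higher numbers stand for weaker inhibition and lower numbers for stronger inhibition), compound 1 `O=C(CC(CC(=O)NC1Cc2ccccc2C1)c1ccc(Cl)cc1)NCCN1CCCC1` reads > 100000 nM, which is a limit and not a number. Compound 2 `CCN(C(=O)CC(CC(=O)NCCN1CCCC1)c1ccc(Cl)cc1)C1Cc2ccccc2C1` gives 55500 nM. Compound 3 `CN(C(=O)CC(CC(=O)NCCN1CCCC1)c1ccccc1)C1Cc2ccccc2C1` reads > 100000 nM, also a limit, so its true position is not known. This is the limit of > 100000 nM in this assay, at which 2 of the 3 values shown sit.

Compound 4 `CN(C(=O)CC(CC(=O)NCCN1CCCC1)c1ccc(Cl)cc1)C1Cc2ccccc2C1` differs from compound 3 by one change, (chloro in place of hydrogen on an aromatic carbon), which turns phenyl into 4-chlorophenyl. For the measured compounds named here, no measured step isolates this change. The only one available is an at least 1.8-fold lower number from compound 1 to compound 2 (0.25 log units; that floor lies within the scatter), which lies on an amide-type nitrogen rather than on the aromatic carbon, and its floor lies within the scatter. It bears on compound 4 only indirectly, since compound 4 shares the 4-chlorophenyl of compound 1 and compound 2. Going by the values given here, with compound 2 at 55500 nM as the one true number, only a small move towards lower numbers is expected, possibly none beyond the scatter. The expected change is an at least 1.2-fold lower number from compound 3 to compound 4 (0.09 log units; that floor lies within the scatter). Compound 4 is estimated at 80000 nM, with an expected range of 35000 nM to 150000 nM.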

Compound 4, half-maximal inhibitory concentration: 83800 nM
Estimate against measurement, compound 4: 1.0-fold (0.02 log units) below; measured number inside the range.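

In this assay the change from phenyl to 4-chlorophenyl now has a step of its own, an at least 1.1-fold lower number from compound 3 to compound 4 (0.07 log units; that floor lies within the scatter). That step is only a floor because compound 3 reads as a limit and not as a number: the limit of > 100000 nM in this assay, at which 2 of the 4 values shown sit. On the amide-type nitrogen, methyl in place of hydrogen gives an at least 1.1-fold lower number from compound 1 to compound 4 (0.07 log units; that floor lies within the scatter), and the step between the two alkyl groups reads a 1.5-fold higher number from compound 2 to compound 4 (0.18 log units; within the scatter), so compound 2 and compound 4 are not separated and the ethyl group shows no gain over the methyl group.

Going by these compounds, it remains open whether a group other than chloro on the aromatic carbon, such as methoxy or an amine, would move the number beyond the scatter. On these data alone, it is equally open whether a longer chain such as propyl on the amide-type nitrogen would do so.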